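A few compounds are considered here, and "the series" means these few. Any claim that something is new, unique, unknown or untested is made for them only; others in the source may bear on it.

Three compounds have been measured in a functional assay on SW-620 cells (Homo sapiens) for inhibition, read by sulforhodamine B assay, with a stated time of 48 h; on this read-out higher numbers stand for weaker inhibition of growth and lower numbers for stronger inhibition of growth:

compound 1 `N#C/C(=C\N1CCN(C(=O)c2ccco2)C1=S)C(N)=O` gives 22100 nM
compound 2 `COc1cc(C(=O)N2CCN(C=O)C2=S)cc(OC)c1OC` gives 26800 nM
compound 3 `O=CN1CCN(C(=O)c2ccco2)C1=S` gives 5500 nM

Among these three numbers compound 1 stands second highest. Compound 2 lies within the usual scatter of compound 1, so the two cannot be told apart on these data. Compound 3, which shares the same core, gives a lower number than compound 1 and that gap lies beyond the scatter, so compound 3 shows the stronger growth inhibition of the pair in this assay.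

The piece now turns to compound 4 `N#C/C(=C\N1CCN(C(=O)c2ccco2)C1=S)C(=O)Nc1ccc(Cl)cc1`, which has not yet been measured. It differs from compound 1 in one place: 4-chlorophenyl in place of hydrogen on an amide-type nitrogen. For the measured compounds named here, no step between two measured compounds that differ in one place is available, so the size of this step has to be judged from the structural change alone.

The expectation is that the step from compound 1 to compound 4 in this assay will run toward a lower number, of a moderate size that may reach beyond the scatter, with a 2.5-fold lower number from compound 1 to compound 4 (0.39 log units; beyond the scatter). On that basis compound 4 is estimated to give 9000 nM in this assay, with a range from 3000 nM to 30000 nM.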

Compound 4, concentration for 50% growth inhibition: 17300 nM
Compound 4: middle estimate off by 1.9-fold (0.28 log units), on the low side, and the stated range covers the measured number.
By their numbers in this assay, from the lowest: compound 3; then compounds 4, 1 and 2 (each within the scatter of the next).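

In this assay, putting 4-chlorophenyl in place of hydrogen on the amide-type nitrogen gives a 1.3-fold lower number from compound 1 to compound 4 (0.11 log units; within the scatter), so compound 1 and compound 4 cannot be told apart on these data. For the compounds shown here, this is the first direct reading of a change at this position, which the earlier compounds could not give, and it shows that a hydrogen can be replaced there by a much larger aromatic group without a shift that stands clear of the usual scatter of the assay. Nothing measured in the material shown accounts for this result.

The compounds shown leave open whether the chlorine plays any part in this reading, which phenyl without a substituent on the same nitrogen would address, and whether a small group such as methyl would read the same way. They also leave open whether a group carrying an amine or a carboxylic acid on this nitrogen would move the number beyond the scatter, since a single step at this position cannot show how far this tolerance extends.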